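Same Aryl Swap on a Second Core: Expected Cytotoxicity

The source may report more compounds than this note shows. Statements on the series, on what has been measured and on what is new or still open speak of the compounds shown alone.

Measured compounds:
- compound 1, `CNC(=O)c1cc(Oc2ccc(NC(=O)c3nn(-c4ccccc4OC(F)(F)F)c(=O)cc3C)cc2F)ccn1`: > 40000 nM
- compound 2, `CNC(=O)c1cc(Oc2ccc(NC(=O)c3nn(-c4cccc(F)c4)c(=O)cc3C)cc2F)ccn1`: 10200 nM
- compound 3, `Cc1cc(=O)n(-c2ccccc2OC(F)(F)F)nc1C(=O)Nc1ccc(Oc2ncnc3ccsc23)cc1`: 25000 nM

The read-out is a functional assay on HepG2 cells (Homo sapiens) for cytotoxicity, read by MTT assay, with a stated time of 72 h; on this read-out lower numbers stand for stronger inhibition and higher numbers for weaker inhibition. For compound 1 the value > 40000 nM is a limit of the assay, not a number, as the limit of > 40000 nM in this assay, at which 1 of the 3 values shown sits, marks. Compound 2 differs from compound 1 in one place: 3-fluorophenyl in place of 2-(trifluoromethoxy)phenyl on an aromatic nitrogen. That change gave an at least 3.9-fold lower number from compound 1 to compound 2 (0.59 log units; beyond the scatter).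

Compound 3 carries a different core; the difference between the two cores is not broken down here. Compound 4, `Cc1cc(=O)n(-c2cccc(F)c2)nc1C(=O)Nc1ccc(Oc2ncnc3ccsc23)cc1`, stands to compound 3 exactly as compound 2 stands to compound 1: 3-fluorophenyl in place of 2-(trifluoromethoxy)phenyl on an aromatic nitrogen. Both place lines read the same word for word, so this is the same change, made on the other core.

Compound 3 gives 25000 nM, so there is room for the number to fall. Resting on the step from compound 1 to compound 2, an at least 3.9-fold lower number from compound 1 to compound 2 (0.59 log units; beyond the scatter), compound 4 is expected to show a step of about a 3.8-fold lower number from compound 3 to compound 4 (0.59 log units; beyond the scatter). Because that earlier step, an at least 3.9-fold lower number from compound 1 to compound 2 (0.59 log units; beyond the scatter), starts from a limit, its true size is uncertain, so the expected range is kept wide. The estimate for compound 4 is 6500 nM, between 2000 nM and 16000 nM.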

Compound 4, half-maximal inhibitory concentration: 10200 nM
Compound 4: middle estimate off by 1.6-fold (0.20 log units), on the low side; the measured number falls inside the stated range.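

On the second core, in this assay, 3-fluorophenyl in place of 2-(trifluoromethoxy)phenyl on an aromatic nitrogen gave a 2.5-fold lower number from compound 3 to compound 4 (0.39 log units; beyond the scatter). The change therefore lowers the number on both cores shown, which is a first sign that its direction carries over in this small set, and the two steps compare as follows: the same change on two cores in this assay, an at least 3.9-fold lower number (0.59 log units; beyond the scatter) from compound 1 to compound 2 and a 2.5-fold lower number (0.39 log units; beyond the scatter) from compound 3 to compound 4; the limit leaves it open whether they differ. It does not show that the size of the step carries over, since the starting point on the first core, for compound 1, is a limit of the assay and not a number: the limit of > 40000 nM in this assay, at which 1 of the 4 values shown sits.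

The two aryl groups differ both in their substituent and in where it sits on the phenyl ring, so the compounds shown cannot say which of these matters. They also leave open whether the same trend would hold on further cores, or with other groups on that nitrogen, such as a phenyl ring carrying an amine or a carboxylic acid.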